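The compounds below may be only part of what the source reports. "The series", "measured", "known", "first", "only" and "open" are said of these compounds alone.

Compound 1 `Cc1ccc(C2=NN(c3nc(-c4ccccc4)cs3)C(c3ccc(F)cc3)C2)s1` is the reference point of the series. In an ADME assay on NIH3T3 cells (Mus musculus) for cytotoxicity, read by XTT assay, with a stated time of 24 h (a lower number here means a stronger inhibitor, a higher number a weaker inhibitor), compound 1 gives only a limit, > 500 ug/mL. Compound 2 `Fc1ccc(C2CC(c3ccc(Cl)s3)=NN2c2nc(-c3ccc(Br)cc3)cs2)cc1` likewise reaches only a limit in this assay, > 500 ug/mL. Compound 3 `CS(=O)(=O)c1ccc(-c2csc(N3N=C(c4ccc(Cl)s4)CC3c3ccc(F)cc3)n2)cc1` also stands at a limit in this assay, > 500 ug/mL. All three values are thus limits, (the limit of > 500 ug/mL in this assay, at which 3 of the 3 values shown sit). Going by the values given here, the single measured step, a step that the two limits leave unreadable from compound 2 to compound 3, concerns another substituent and its size cannot be read. Compound 4 `Cc1ccc(C2=NN(c3nc(-c4ccc(C(F)(F)F)cc4)cs3)C(c3ccc(F)cc3)C2)s1` differs from compound 1 by trifluoromethyl in place of hydrogen on an aromatic carbon. Among the compounds with values here, no measured step bears on this change with a readable size, so nothing points away from the limit. The expected step that the limit leaves unreadable from compound 1 to compound 4 is none beyond the scatter. Compound 4 is estimated at 700 ug/mL in this assay, with a range from 350 ug/mL to 1500 ug/mL.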

Compound 4, half-maximal inhibitory concentration: > 500 ug/mL
Compound 4: only a limit was reported; the forecaster's own chance of this, stated with the estimate: 85%; the middle value lies beyond the limit too.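

Compound 1 and compound 4 both give only limits in this assay, so no step can be read for trifluoromethyl in place of hydrogen: the limit of > 500 ug/mL in this assay, at which 4 of the 4 values shown sit. The compounds shown leave open whether any change on the shared core gives a measurable value in this assay at all.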